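The compounds below may be only part of what the source reports. "The series", "measured", "known", "first", "only" and "open" are said of these compounds alone.

Measured compounds in hand:

- compound 1, `O=C(Nc1cccc(-n2cc(-c3ccncc3)c(-c3cc(O)cc(Cl)c3)n2)c1)Nc1ccc(Cl)c(Cl)c1`: 2.26%
- compound 2, `COc1cc(Cl)cc(-c2nn(-c3cccc(NC(=O)Nc4ccc(Cl)c(Cl)c4)c3)cc2-c2ccncc2)c1`: 14.4%
- compound 3, `O=C(Nc1cccc(-n2cc(-c3ccncc3)c(-c3cc(O)cc(Cl)c3)n2)c1)c1cc(C(F)(F)F)cc(C(F)(F)F)c1`: 21.2%

All three were run in a functional assay on KM12 cells (Homo sapiens) for inhibition, read by sulforhodamine B assay, with a stated time of 48 h, tested at 10 uM; on this read-out lower numbers stand for a stronger effect and higher numbers for a weaker effect at the one concentration tested. Compound 1 gives 2.26% and compound 2 gives 14.4%; the pair differ only by methyl in place of hydrogen on an oxygen on an aromatic ring, and this change gave a number 12.1 percentage points higher from compound 1 to compound 2 (beyond the scatter). Compound 3 gives 21.2%, which stands within the scatter of compound 2 and beyond the scatter of compound 1. The difference between the core of compound 1 and the core of compound 3 is not broken down here.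

Compound 4, `COc1cc(Cl)cc(-c2nn(-c3cccc(NC(=O)c4cc(C(F)(F)F)cc(C(F)(F)F)c4)c3)cc2-c2ccncc2)c1`, has not yet been measured in this assay. It differs from compound 3 by methyl in place of hydrogen on an oxygen on an aromatic ring, the same change as that from compound 1 to compound 2, made on the same place. Among the compounds shown this change occurs twice in all, so only one measured step speaks to it.

The expectation for compound 4 in this assay rests on that single step: the change from compound 1 to compound 2 gave a number 12.1 percentage points higher from compound 1 to compound 2 (beyond the scatter), and a step of similar size and direction is expected here, a number 11.8 percentage points higher from compound 3 to compound 4 (beyond the scatter). Among the measured compounds shown here, the reference is only one pair, and compound 3 starts from a different core than compound 1. The range is therefore kept wide. Compound 4 is estimated to give 33%, with the expected range running from 15% to 52%.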

Compound 4, a percentage reported as activity, at one concentration (the size of the read-out at that concentration, not a potency): 55.5%
Compound 4: middle estimate off by 22.5 percentage points, on the low side, and the stated range ends below it.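

In this assay, going from hydroxy to methoxy on the 3-chloro-5-hydroxyphenyl group weakens the effect again, giving a number 34.3 percentage points higher from compound 3 to compound 4 (beyond the scatter). The direction of this change carries from one core to the other in the two pairs available, but its size does not: the same change on two cores in this assay, a number 12.1 percentage points higher (beyond the scatter) from compound 1 to compound 2 and a number 34.3 percentage points higher (beyond the scatter) from compound 3 to compound 4, 22.2 percentage points apart, beyond the scatter of two such steps

So a step measured on one core in this series gives the likely sign on the other, but not a usable size. These two pairs do not show which part of the difference between the core of compound 1 and the core of compound 3 sets the size of the step, nor do they show that the direction would hold on a third core, and a reading at one concentration says nothing about potency.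

The compounds shown leave open how the effect responds to anything on that oxygen other than hydrogen or methyl, such as an ethyl group or a longer chain. They also leave open whether an amine or a carboxylic acid in place of the hydroxy would keep the effect seen with the hydroxy compounds on either core.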